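Removing a methyl from compound 2's methoxy

The source may hold more compounds than are shown below. What is called first, only, known or untested is meant among the compounds shown, and "the series" means these compounds.

Compound 1 `c1cc(C2=NCCN2)cc(-c2cc3ccc(C4=NCCN4)cc3o2)c1`: 12800 nM
Compound 2 `COc1ccc(C2=NCCN2)cc1-c1cc2ccc(C3=NCCN3)cc2o1`: 11100 nM

In an ADME assay on L6 cells (Rattus norvegicus) for cytotoxicity (a lower number here means a stronger inhibitor, a higher number a weaker inhibitor), compound 2 gives 11100 nM, and it cannot be told apart from compound 1, which gives 12800 nM. Compound 3 `Oc1ccc(C2=NCCN2)cc1-c1cc2ccc(C3=NCCN3)cc2o1` has not yet been measured. It differs from compound 2 by hydrogen in place of methyl on an oxygen on an aromatic ring, or methoxy to hydroxy.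

Within the data shown here, only one measured step bears on this change: a 1.2-fold lower number from compound 1 to compound 2 (0.06 log units; within the scatter), where methoxy took the place of hydrogen on an aromatic carbon. Among the measured compounds shown here, that is a different change, and no hydroxy compound has been measured, so it is only a loose guide. Even so, no step beyond the scatter is expected in this assay. The expected change is a 1.0-fold lower number from compound 2 to compound 3 (0.00 log units; within the scatter). Compound 3 is estimated at 11000 nM, with an expected range of 5000 nM to 25000 nM.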

Compound 3, half-maximal inhibitory concentration: > 189000 nM
Compound 3: a limit, no number (the forecaster's own chance of this, stated with the estimate: 5%); at least 17-fold (1.23 log units) between middle value and limit.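

In this assay, among these compounds, this position turns out to be sensitive to what it carries: hydrogen in place of methyl on the oxygen gives an at least 17-fold higher number from compound 2 to compound 3 (1.23 log units; beyond the scatter), whereas the one earlier change here, methoxy for hydrogen, gave only a 1.2-fold lower number from compound 1 to compound 2 (0.06 log units; within the scatter). Hydroxy in place of hydrogen on the same aromatic carbon gives an at least 14-fold higher number from compound 1 to compound 3 (1.16 log units; beyond the scatter), so methoxy and hydroxy are not interchangeable at this place, which the earlier pair could not reveal. Compound 3 has a limit of the assay and not a number, so the full size of both new steps stays unknown: the limit of > 189000 nM in this assay, at which 1 of the 3 values shown sits.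

The compounds shown leave open whether an amine or a fluorine at this place would track hydroxy or methoxy. They also leave open whether ethoxy, with a longer chain on the oxygen, would stay close to methoxy.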